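A few compounds are considered here, and "the series" means these few. Any claim that something is new, unique, unknown or untested is made for them only; others in the source may bear on it.

Measured so far:
- compound 1 `CC1CCN(c2nc(Cl)nc3c2ncn3Cc2ccc(/C=C/C(=O)Nc3ccccc3N)cc2)CC1` gives 4.24% in a functional assay on HCT-116 cells (Homo sapiens) for antiproliferative activity, read by CCK-8 assay, with a stated time of 72 h, tested at 2 uM; on this read-out higher numbers stand for a stronger effect at the one concentration tested and lower numbers for a weaker effect
- compound 2 `Nc1ccccc1NC(=O)c1ccc(Cn2cnc3c(NCc4ccccc4)nc(Cl)nc32)cc1` gives 68.3% in this assay
- compound 3 `Nc1ccccc1NC(=O)/C=C/c1ccc(Cn2cnc3c(Nc4cccc(OC(F)(F)F)c4)nc(Cl)nc32)cc1` gives 2.8% in this assay

Compound 3 has the lowest of the three numbers, though compound 1 sits within the scatter of it; only compound 2 stands well beyond it. Compound 4 `Nc1ccccc1NC(=O)/C=C/c1ccc(Cn2cnc3c(NCc4ccccc4)nc(Cl)nc32)cc1` is the next compound, and it differs from compound 3 in one place: benzyl in place of 3-(trifluoromethoxy)phenyl on a nitrogen on an aromatic ring. For the measured compounds named here, no measured step changes this group on a shared core, so the only guide is indirect. Going by the values given here, the one measured step, a number 1.4 percentage points lower from compound 1 to compound 3 (within the scatter), exchanges a different group at the same nitrogen and stays within the scatter. Compound 2 carries the same benzylamino group as compound 4 but on a different linker, and its value is far higher than that of compound 3. Compound 4 is therefore expected to rise above compound 3, but by an uncertain amount, with an estimated step of a number 32.2 percentage points higher from compound 3 to compound 4 (beyond the scatter). For compound 4 the estimated value is 35%, within a range from 5% to 75%.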

Compound 4, a percentage reported as inhibition, at one concentration (the size of the read-out at that concentration, not a potency): 2.85%
Compound 4: middle estimate off by 32.2 percentage points, on the high side; measured number below the stated range.
By their numbers in this assay, from the lowest: compounds 3, 4 and 1 (each within the scatter of the next); then compound 2.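

In this assay, the group on this nitrogen makes no readable difference on the core that carries the ethenyl linker: benzyl in place of 3-(trifluoromethoxy)phenyl gives a number 0.1 percentage points higher from compound 3 to compound 4 (within the scatter), and benzylamino in place of 4-methylpiperidin-1-yl gives a number 1.4 percentage points lower from compound 1 to compound 4 (within the scatter). The large change lies elsewhere, since with benzylamino held constant, 2-((2-aminophenyl)carbamoyl)ethenyl in place of (2-aminophenyl)carbamoyl on an aromatic carbon gives a number 65.5 percentage points lower from compound 2 to compound 4 (beyond the scatter), which shows that benzylamino alone does not secure a high number. No supporting measurement is available to explain this gap.

Going by these compounds, it remains open whether the group on this nitrogen matters once the linker of compound 2 is present, as that linker appears here with benzylamino only. Also open, on these data alone, is how a phenethyl chain or a cyclohexyl ring on this nitrogen would behave on either linker.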